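Phenoxy to isopropoxy on the aryl oxygen: compound 3

A few compounds are considered here, and "the series" means these few. Any claim that something is new, unique, unknown or untested is made for them only; others in the source may bear on it.

Measured so far:
compound 1, `C1=C(c2cccnc2)C[C@@H]2CNC[C@H]1C2`, gives 139% in an in vitro functional assay on SH-SY5Y cells for agonist activity at Neuronal acetylcholine receptor; alpha3/beta4 (Homo sapiens), read by FLIPR and calcium flux; a lower number here means a smaller maximal response, a higher number a larger maximal response
compound 2, `C1=C(c2cncc(Oc3ccccc3)c2)CC2CNCC1C2`, gives 101% in this assay

Compound 2 stands at the lower of the two numbers. Its nearest neighbour in this assay is compound 1, whose maximal response lies higher by a margin that is beyond the usual scatter; the two compounds differ in more than one place, so the gap between them is taken only as what the two values show.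

Compound 3, `CC(C)Oc1cncc(C2=CC3CNCC(C2)C3)c1`, has not yet been measured. It differs from compound 2 in one place: isopropyl in place of phenyl on an oxygen on an aromatic ring. The aromatic ring that carried the phenoxy group, the oxygen and the core are unchanged.

For the measured compounds named here, no pair of measured compounds shows this difference, so there is no step to lean on. With nothing in the series pointing either way, the expected step from compound 2 to compound 3 in this assay, a number 4 percentage points higher from compound 2 to compound 3 (within the scatter), is small and not beyond the scatter in either direction. The maximal response of compound 3 is therefore estimated at 105%, within a range from 80% to 135%.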

Compound 3, largest response reached (reported as percent of maximum), in percent of the reference or control that the assay uses: 160%
Compound 3: the middle estimate sits 55 percentage points below what was measured, outside the stated range (above it).
By their numbers in this assay, from the lowest: compound 2; then compound 1; then compound 3.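

In this assay, isopropyl in place of phenyl on an oxygen on an aromatic ring gives a number 59 percentage points higher from compound 2 to compound 3 (beyond the scatter). For the compounds shown here, this is the first single-place step, and it shows that the maximal response is sensitive to the group carried by this oxygen, with the aromatic ring, the oxygen and the core held constant. Nothing measured accounts for the size or direction of this step.

The step rests on one pair, and the change both removes an aromatic ring and lowers the heavy-atom count, so the compounds shown cannot separate these two differences or show whether the trend extends to other groups. Cyclopentyl or cyclohexyl on the same oxygen would keep a ring without aromaticity, while methyl or a longer chain such as n-butyl would show how the response follows the size of an open-chain group, and an amine in place of the oxygen would test whether the oxygen itself matters.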